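The compounds below may be only part of what the source reports. "The series", "measured", "known", "first", "only" and "open" are said of these compounds alone.

Measured in a functional assay on KB cells (Homo sapiens) for cytotoxicity; on this read-out higher numbers stand for weaker inhibition and lower numbers for stronger inhibition:
- compound 1 `COC(=O)c1ccc(C(=O)Nc2cccc3c2N(S(=O)(=O)c2ccc(OC)cc2)CC3)cc1`: 376 nM
- compound 2 `COc1ccc(S(=O)(=O)N2CCc3cccc(NC(C)=O)c32)cc1`: 89 nM

Compound 2, at 89 nM, holds the lower of the two numbers in this assay, so it is the stronger inhibitor of the pair.

The next compound is compound 3 `COc1ccc(S(=O)(=O)N2CCc3cccc(NC(=O)c4ccccc4)c32)cc1`. The change is phenyl in place of methyl on a carbonyl carbon, in words phenyl in place of methyl on a carbonyl carbon.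

For the measured compounds named here, one measured step bears on this: a 4.2-fold lower number from compound 1 to compound 2 (0.63 log units; beyond the scatter), with methyl in place of 4-(methoxycarbonyl)phenyl on a carbonyl carbon. Read in reverse, that step suggests a ring at this place raises the number by a modest amount. Compound 3 lacks the methoxycarbonyl group, and the data do not separate the ring from that group. A single step is thin evidence.

A modest rise is therefore expected, the estimated change being a 2.4-fold higher number from compound 2 to compound 3 (0.37 log units; beyond the scatter). For compound 3 the estimate is 210 nM, with an expected range of 75 nM to 600 nM.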

Compound 3, half-maximal inhibitory concentration: 297 nM
The estimate for compound 3 lay 1.4-fold (0.15 log units) below the measured number; the measured number falls inside the stated range.
By their numbers in this assay, from the lowest: compound 2; then compounds 3 and 1 (each within the scatter of the next).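

In this assay, a ring on this carbonyl carbon still gives a higher number without the methoxycarbonyl group: phenyl in place of methyl gives a 3.3-fold higher number from compound 2 to compound 3 (0.52 log units; beyond the scatter) in this series. Hydrogen in place of methoxycarbonyl on an aromatic carbon gives a 1.3-fold lower number from compound 1 to compound 3 (0.10 log units; within the scatter) and so does not separate compound 1 from compound 3, which places the difference from compound 2 with the ring and not with that ester group. Nothing available explains why benzamido and acetamido differ in this way.

Open, as far as these compounds go, is whether a saturated ring such as cyclohexyl, or a longer chain such as propyl, would match phenyl or methyl at this place. Also open, from the compounds shown here alone, is whether an amine or a carboxylic acid on an aromatic carbon of the phenyl would move the number, as methoxycarbonyl did not.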